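The source may report more compounds than this note shows. Statements on the series, on what has been measured and on what is new or still open speak of the compounds shown alone.

For the measured compounds named here, in an assay on isolated protein for displacement of a labelled ligand from sodium-dependent dopamine transporter (Rattus norvegicus), with a stated time of 5 min (on this read-out lower numbers stand for stronger inhibition and higher numbers for weaker inhibition), compound 2 `Oc1ccc(CN[C@H]2CO[C@H](C(c3ccccc3)c3ccccc3)C2)cc1` gives 3690 nM, the higher of the two numbers measured so far. Compound 1 `Oc1ccc(CN[C@H]2CC[C@@H](CCC(c3ccccc3)c3ccccc3)OC2)cc1` gives 45.7 nM in this assay, and the gap between these two lies beyond the usual scatter. Compound 3 `Oc1ccc(CN[C@@H]2CO[C@H](C(c3ccccc3)c3ccccc3)C2)cc1` is the unmeasured partner of compound 2: the two compounds have the same atoms and bonds and differ only in configuration as drawn: 1 of 2 stereo elements differ; a stereocentre at a saturated ring carbon is drawn R in compound 2 and S in compound 3. Going by the values given here, no pair of measured compounds differing at a single point is available, so the size of such an inversion on this read-out is unknown; a shift in either direction is possible, and a moderate move to a lower number is taken as the working guess. For compound 3 the expected value in this assay is 1500 nM, within 250 nM to 9000 nM. That amounts to an expected step of a 2.5-fold lower number from compound 2 to compound 3 (0.39 log units; beyond the scatter).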

Compound 3, inhibition constant: 943 nM
Estimate against measurement, compound 3: 1.6-fold (0.20 log units) above; measured number inside the range.
By their numbers in this assay, from the lowest: compound 1; then compound 3; then compound 2.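

In this assay, inverting a saturated ring carbon from R to S gives a 3.9-fold lower number from compound 2 to compound 3 (0.59 log units; beyond the scatter). For the compounds shown here, this is the first single-point step, and it shows that configuration at this carbon alone can move the number beyond the scatter, though only modestly. The step can be assigned to this stereocentre: the fact that compounds 2 and 3 differ only in the configuration as drawn.

From the compounds shown here alone, the effect of inverting the other stereo element remains open. Also open, going by these compounds, is whether this inversion gives a step of similar size and direction with a methoxy group in place of the hydroxyl.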